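Methyl on the Benzyl Ring of a Benzamide Inhibitor

A few compounds are considered here, and "the series" means these few. Any claim that something is new, unique, unknown or untested is made for them only; others in the source may bear on it.

Compound 1 `O=C(Nc1ccccn1)c1ccccc1OCc1ccccc1`: 11700 nM
Compound 2 `O=C(Nc1cccnc1)c1ccccc1OCc1ccccc1`: 3200 nM

Among the compounds with values here, in an assay on lysate for inhibition of phosphatidylcholine:ceramide cholinephosphotransferase 2 (Homo sapiens), read by HPLC, with stated times of 30 min and 2 h (on this read-out lower numbers stand for stronger inhibition and higher numbers for weaker inhibition), compound 2 holds the lower of the two numbers, and the one measured step, a 3.7-fold lower number from compound 1 to compound 2 (0.56 log units; beyond the scatter), swaps pyridin-3-yl for pyridin-2-yl on an amide-type nitrogen. Compound 3 `Cc1ccccc1COc1ccccc1C(=O)Nc1cccnc1` keeps that pyridin-3-yl and differs from compound 2 only by methyl in place of hydrogen on an aromatic carbon. No measured step touches the benzyl side, so nothing shown bears on this change, and a step within the scatter is the plain expectation. Compound 3 is therefore estimated at 3000 nM, within 1000 nM to 9000 nM, a step of a 1.1-fold lower number from compound 2 to compound 3 (0.03 log units; within the scatter) expected.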

Compound 3, half-maximal inhibitory concentration: 1500 nM
Estimate against measurement, compound 3: 2.0-fold (0.30 log units) above, within the range that was stated.
By their numbers in this assay, from the lowest: compound 3; then compound 2; then compound 1.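

Replacing hydrogen with methyl on the benzyl ring gives a 2.1-fold lower number from compound 2 to compound 3 (0.33 log units; beyond the scatter) and shows that this side of the molecule, untouched by the earlier step, can also shift the number. The change from benzyl to 2-methylbenzyl adds only one carbon, ortho to a large group, yet it leaves compound 3 with the lowest number of the three. Nothing given here explains this shift.

From the compounds shown here alone, it remains open whether an ethyl, a methoxy or a chlorine at this place would have a similar effect. It is also unknown whether methyl elsewhere on the ring, or on the pyridin-2-yl amide of compound 1, would lower the number.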